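Sulfonamide aryl swap in the benzofuran series

The source may report more compounds than this note shows. Statements on the series, on what has been measured and on what is new or still open speak of the compounds shown alone.

Compound 1 `CCOC(=O)c1oc2ccc(NS(=O)(=O)c3cccc(Cl)c3)cc2c1C` gives 53700 nM in a functional assay on MDA-MB-468 cells (Homo sapiens) for antiproliferative activity, read by MTT assay, with a stated time of 72 h; on this read-out lower numbers stand for stronger inhibition and higher numbers for weaker inhibition. Compound 2 `CCOC(=O)c1oc2ccc(NS(=O)(=O)c3ccc(Br)cc3)cc2c1C` gives 26400 nM in this assay and so holds the lowest of the two numbers measured; the step of a 2.0-fold lower number from compound 1 to compound 2 (0.31 log units; beyond the scatter) is the only one recorded and it is modest. Compound 3 `CCOC(=O)c1oc2ccc(NS(=O)(=O)c3ccccc3[N+](=O)[O-])cc2c1C` is not yet measured. Relative to compound 2 the change is 2-nitrophenyl in place of 4-bromophenyl on a sulfonyl sulfur. Among the measured compounds shown here, no measured step bears directly on a nitro group on this phenyl ring; the single step from compound 1 to compound 2 concerns halogen identity and position, and it stayed modest. On that basis the step of a 1.3-fold higher number from compound 2 to compound 3 (0.12 log units; within the scatter) is expected to be small, with no strong reason for either direction, and weak activity is expected to persist. Compound 3 is therefore estimated at 35000 nM in this assay, within a range from 12000 nM to 100000 nM.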

Compound 3, half-maximal inhibitory concentration: 96900 nM
Compound 3: the middle estimate sits 2.8-fold (0.44 log units) below what was measured; the measured number falls inside the stated range.
By their numbers in this assay, from the lowest: compound 2; then compounds 1 and 3 (each within the scatter of the next).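

The step of a 3.7-fold higher number from compound 2 to compound 3 (0.56 log units; beyond the scatter) in this assay shows that the aryl group on the sulfonyl sulfur can move the number through a change other than a halogen swap, here with 2-nitrophenyl on the weaker side of 4-bromophenyl. The step of a 1.8-fold higher number from compound 1 to compound 3 (0.26 log units; within the scatter) leaves 2-nitrophenyl and 3-chlorophenyl indistinguishable, so among these three aryl groups only 4-bromophenyl stands apart, and even its number remains in the high range of the series. Nothing available explains why these aryl groups differ.

Halogen identity and placement change together between 3-chlorophenyl and 4-bromophenyl, so their contributions cannot be separated in this set. On these data alone, whether an amine or a carboxylic acid on this phenyl ring would shift the number in either direction stays open.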